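The source may report more compounds than this note shows. Statements on the series, on what has been measured and on what is new or still open speak of the compounds shown alone.

In an ADME assay for permeability, using PAMPA, at pH 7.4 (on this read-out higher numbers stand for higher permeability and lower numbers for lower permeability), compound 1 `CCc1ccc(NC(=O)Nc2cc(C)nc3ccccc23)cc1` gives 535 10^-6 cm/s and compound 2 `Cc1cc(NC(=O)Nc2ccc(F)c(F)c2)c2ccccc2n1` gives 478 10^-6 cm/s. These two values lie within the scatter of each other, so compound 1 stands level with compound 2 at the top of the small range seen so far. For the measured compounds named here, the two compounds do not differ in one place only, so no measured single-change step is available as a guide.

The next compound to be read is compound 3 `Cc1cc(NC(=O)Nc2ccc(C(F)(F)F)cc2)c2ccccc2n1`. It has trifluoromethyl in place of ethyl on an aromatic carbon, para to a large group, relative to compound 1: trifluoromethyl in place of ethyl on an aromatic carbon.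

No step beyond the scatter is expected in this assay, and no direction is favoured with confidence. This expectation rests on compound 2, which carries fluorine and gives 478 10^-6 cm/s, a value not separated from that of compound 1. Going by the values given here, with only two measured compounds, the support is thin. The expected change is a 1.2-fold lower number from compound 1 to compound 3 (0.08 log units; within the scatter). For compound 3 the estimated value is 450 10^-6 cm/s, with an expected range of 220 10^-6 cm/s to 900 10^-6 cm/s.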

Compound 3, apparent permeability: 2 10^-6 cm/s
Estimate against measurement, compound 3: 230-fold (2.35 log units) above; the whole stated range lies above it.
By their numbers in this assay, from the lowest: compound 3; then compounds 2 and 1 (each within the scatter of the next).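

In this assay, for the compounds shown here, this position, on an aromatic carbon para to a large group, is not a neutral place for change: trifluoromethyl in place of ethyl gives a 270-fold lower number from compound 1 to compound 3 (2.43 log units; beyond the scatter), a step of a kind that the earlier compounds, with no single-change pair among them, could not show. The step is tied to this one exchange, and the shared core is unchanged; neither group brings a ring, a hydrogen-bond donor, a hydrogen-bond acceptor or a net charge, so these counted features do not separate compound 1 from compound 3. Nothing measured here accounts for the size of this step.

A single step cannot show whether the fall belongs to the arrival of trifluoromethyl in particular or to the loss of ethyl, and it gives no trend across substituents at this place. A methyl, a chlorine, a methoxy group or a longer alkyl chain on the same aromatic carbon, each set against compound 1, would show whether the read-out changes gradually or falls only with trifluoromethyl.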